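This account rests on a few compounds, and the source may have more. Where it says the series, first, only, none or still open, it means among the compounds named here.

Of the compounds shown here, two built on one shared core have so far been measured in a functional assay (trachea) with Cavia porcellus as the target; a higher number here means a weaker inhibitor, a lower number a stronger inhibitor. Compound 1 `O=c1c2ccccc2c(-c2cccnc2)nn1Cc1cccc(Cl)c1` carries a 3-chlorobenzyl group, and in this assay compound 1 gives 4170 nM. Compound 2 `O=c1c2ccccc2c(-c2cccnc2)nn1S(=O)(=O)c1ccccc1` carries a different group at the same point, and in this assay compound 2 gives 14800 nM. Of these two numbers, that of compound 1 is the lower, and the gap between them lies beyond the usual scatter, so compound 1 is the stronger inhibitor of the pair.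

Compound 3 `NCCn1nc(-c2cccnc2)c2ccccc2c1=O` differs from compound 1 in a single place: aminomethyl in place of 3-chlorophenyl on a saturated chain carbon bound to an aromatic nitrogen. Cut one bond further out, the same change reads 3-chlorobenzyl to 2-aminoethyl. Among the compounds with values here, no measured pair among the compounds shows what this change does to the number, so the expectation rests on the structural change alone. The expected step is a 3.6-fold higher number from compound 1 to compound 3 (0.56 log units; beyond the scatter), toward a higher number and larger than the scatter. Compound 3 is therefore estimated at 15000 nM, with a range from 4000 nM to 60000 nM.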

Compound 3, half-maximal inhibitory concentration: > 100000 nM
Compound 3: a limit, no number; the forecaster's own chance of this, stated with the estimate: 25%; middle value at least 6.6-fold (0.82 log units) away from the limit.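

In this assay compound 3 gives > 100000 nM, which is a limit of the assay and not a number. The step reads an at least 23-fold higher number from compound 1 to compound 3 (1.37 log units; beyond the scatter), so on the saturated chain carbon bound to an aromatic nitrogen, aminomethyl in place of 3-chlorophenyl costs far more than the spread between compound 1 and compound 2 would have suggested, and it gives this place its first readable step. The step gives only a minimum size and its full extent stays unknown, because the number for compound 3 is cut off by the limit of the assay: the limit of > 100000 nM in this assay, at which 1 of the 3 values shown sits.

The change removes an aromatic ring and brings in an amine in one move, so the compounds shown cannot tell whether the loss follows from the missing 3-chlorophenyl, from the new amine, or from both. An unsubstituted benzyl, a benzyl carrying an amine, a plain ethyl or a longer chain ending in an amine would pull these apart, and none of them stands among the three compounds here.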